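Swapping the alkyne end of the amide chain in compound 3

This account rests on a few compounds, and the source may have more. Where it says the series, first, only, none or still open, it means among the compounds named here.

In a functional assay on MIA PaCa-2 cells (Homo sapiens) for antiproliferative activity (a lower number here means that less compound is needed, a higher number that more compound is needed for the effect), compound 1 `Cc1cc2c(C(N)=O)cccc2n1-c1nc2c(c(NCc3ccccc3)n1)CCCC2` gives 128 nM, compound 2 `Cc1cc2c(C(=O)NCC#N)cccc2n1-c1nc2c(c(NCc3ccccc3)n1)CCCC2` gives 468 nM and compound 3 `CC#CCNC(=O)c1cccc2c1cc(C)n2-c1nc2c(c(NCc3ccccc3)n1)CCCC2` gives 723 nM. Compound 3 thus stands level with compound 2, as a 1.5-fold higher number from compound 2 to compound 3 (0.19 log units; within the scatter) shows, and clearly off compound 1, as a 5.6-fold higher number from compound 1 to compound 3 (0.75 log units; beyond the scatter) shows. Compound 4 `CCCNC(=O)c1cccc2c1cc(C)n2-c1nc2c(c(NCc3ccccc3)n1)CCCC2` differs from compound 3 at one place: ethyl in place of prop-1-yn-1-yl on a saturated chain carbon bound to an amide-type nitrogen. It carries ethyl in place of prop-1-yn-1-yl on a saturated chain carbon bound to an amide-type nitrogen. Within the data shown here, the closest precedent is a 1.5-fold higher number from compound 2 to compound 3 (0.19 log units; within the scatter), a change at the same carbon. The larger 3.7-fold higher number from compound 1 to compound 2 (0.56 log units; beyond the scatter) replaced the amide hydrogen itself, which compound 4 does not restore. The expected step is a 1.2-fold lower number from compound 3 to compound 4 (0.08 log units; within the scatter), none beyond the scatter. Compound 4 is estimated at 600 nM, with an expected range of 270 nM to 1300 nM.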

Compound 4, half-maximal effective concentration: 608 nM
Estimate against measurement, compound 4: 1.0-fold (0.01 log units) below; low and high end bracket the measured number.
By their numbers in this assay, from the lowest: compound 1; then compounds 2, 4 and 3 (each within the scatter of the next).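

Removing the triple bond leaves the level of the amide chain intact (a 1.2-fold lower number from compound 3 to compound 4 (0.08 log units; within the scatter)), and ethyl and cyano at this carbon also stand level (a 1.3-fold higher number from compound 2 to compound 4 (0.11 log units; within the scatter)). In this assay, prop-1-yn-1-yl, cyano and ethyl at this saturated chain carbon thus show no difference beyond the scatter. A plain propyl on the amide nitrogen, with no triple bond, stays clearly off the unsubstituted amide (a 4.8-fold higher number from compound 1 to compound 4 (0.68 log units; beyond the scatter)). No measurement here bears on why this is so. From the compounds shown here alone, it remains open whether an amine, a carboxylic acid or a longer chain at this carbon would stay at this level, and whether a methyl on the amide nitrogen would already give the same step.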